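The compounds below may be only part of what the source reports. "The series", "measured", "known", "first", "only" and "open" are said of these compounds alone.

In an ADME assay on Caco-2 cells (Homo sapiens) for permeability, in the apical to basolateral direction, at pH 7.4 (a lower number here means that the compound crosses the layer more slowly, a higher number that the compound crosses the layer faster), compound 1 `O=C(N[C@H]1CN(S(=O)(=O)c2ccccc2)C[C@@H]1C(=O)N[C@H]1CCCNC1)c1cn(C2CC2)cn1` gives 0.48 10^-6 cm/s and compound 2 `O=C(N[C@H]1CN(S(=O)(=O)c2ccccc2)C[C@@H]1C(=O)N[C@H]1CCCNC1)c1cc(-c2ccccc2Cl)on1` gives 0.31 10^-6 cm/s. The step between them is a 1.5-fold lower number from compound 1 to compound 2 (0.19 log units; within the scatter), so compound 2 stands within the scatter of compound 1. Compound 3 `O=C(N[C@H]1CN(S(=O)(=O)c2ccccc2)C[C@@H]1C(=O)N[C@H]1CCCNC1)c1cc(-c2ccc(Cl)cc2Cl)on1` reads < 0.07 10^-6 cm/s, which is a limit of the assay. Chloro in place of hydrogen gives an at least 4.4-fold lower number from compound 2 to compound 3 (0.64 log units; beyond the scatter).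

Compound 4 `CC(=O)N1CCC[C@H](NC(=O)[C@H]2CN(S(=O)(=O)c3ccccc3)C[C@@H]2NC(=O)c2cc(-c3ccccc3Cl)on2)C1` carries acetyl in place of hydrogen on an amine nitrogen in a ring. Neither measured step changes this nitrogen, so neither fixes a size here. Among the compounds with values here, the step of an at least 4.4-fold lower number from compound 2 to compound 3 (0.64 log units; beyond the scatter) shows only that one small change on compound 2 can pass the scatter. A modest rise is expected, resting on the structural change alone. The expected step is a 2.9-fold higher number from compound 2 to compound 4 (0.46 log units; beyond the scatter). For compound 4 the estimate is 0.9 10^-6 cm/s, with an expected range of 0.2 10^-6 cm/s to 3 10^-6 cm/s.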

Compound 4, apparent permeability: 0.75 10^-6 cm/s
Compound 4: the middle estimate sits 1.2-fold (0.08 log units) above what was measured, and the stated range covers the measured number.
By their numbers in this assay, from the lowest: compounds 2, 1 and 4 (each within the scatter of the next, the first and the last beyond it). At a limit, below all of these: compound 3.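

Acetyl in place of hydrogen on the amine nitrogen of the six-membered ring gives a 2.4-fold higher number from compound 2 to compound 4 (0.38 log units; beyond the scatter) in this assay. This is the first step shown at this nitrogen, and the first step beyond the scatter that goes upward; the only earlier step beyond the scatter, on the aromatic ring, goes downward. Nothing measured here gives a reason for this rise. As far as these compounds go, whether a methyl or a longer acyl chain on this nitrogen moves the number in the same way stays open. So does whether acetyl gives a similar step on compound 1.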